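Swapping a Furan Amide Tail for a Carbamate

The source may report more compounds than this note shows. Statements on the series, on what has been measured and on what is new or still open speak of the compounds shown alone.

Of the compounds shown here, three built on one shared core have been tested in a functional assay on PANC-1 cells (Homo sapiens) for inhibition, read by MTT assay, with a stated time of 24 h, tested at 10 uM; a lower number here means less inhibition, a higher number more inhibition at the concentration tested (going by the name of the read-out). Compound 1 `COc1ccccc1NC(=O)Oc1cc(=O)n(CCCO)c2c1CC(CC=C(C)C)C(C)(C)C2` gives 71.1%, compound 2 `CCOc1cc(=O)n(CCCO)c2c1CC(C/C=C(\C)CCC=C(C)C)C(C)(C)C2` gives 67.8%, and compound 3 `CC(C)=CCC/C(C)=C/CC1Cc2c(OCCCNC(=O)c3ccco3)cc(=O)n(CCCO)c2CC1(C)C` gives 69.5%. Compound 3 stands second among the three numbers, but its gap to compound 1 and its gap to compound 2 both lie within the scatter, so the three cannot be told apart. Within the data shown here, the one step measured between two of them, a number 1.7 percentage points higher from compound 2 to compound 3 (within the scatter), came from putting (((furan-2-yl)carbonyl)amino)methyl in place of hydrogen on a saturated chain carbon, two bonds along the chain from an oxygen on an aromatic ring, and it moved nothing beyond the scatter.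

Compound 4 `COc1ccccc1NC(=O)Oc1cc(=O)n(CCCO)c2c1CC(C/C=C(\C)CCC=C(C)C)C(C)(C)C2` has not been measured. It differs from compound 3 in one place: (2-methoxyphenyl)carbamoyl in place of 3-(((furan-2-yl)carbonyl)amino)propyl on an oxygen on an aromatic ring. Among the measured compounds shown here, compound 1 carries the same (2-methoxyphenyl)carbamoyl group and its number sits close to that of compound 3, while the only measured step, a different change on the same oxygen, was flat. For the measured compounds named here, no measured step bears directly on this exchange, so the step expected is a number 0.5 percentage points higher from compound 3 to compound 4 (within the scatter), none beyond the scatter. Compound 4 is therefore estimated at 70%, with a range from 60% to 80%.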

Compound 4, a percentage reported as inhibition, at one concentration (the size of the read-out at that concentration, not a potency): 53%
For compound 4 the middle estimate is 17 percentage points above the measured one; measured number below the stated range.
By their numbers in this assay, from the lowest: compound 4; then compounds 2, 3 and 1 (each within the scatter of the next).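

In this assay the oxygen on an aromatic ring turns out to be sensitive to what it carries: (2-methoxyphenyl)carbamoyl in place of 3-(((furan-2-yl)carbonyl)amino)propyl gives a step beyond the scatter (a number 16.5 percentage points lower from compound 3 to compound 4 (beyond the scatter)), and in place of ethyl it gives another (a number 14.8 percentage points lower from compound 2 to compound 4 (beyond the scatter)). Yet this group alone does not set the number: compound 1 carries it too, and 3-methylbut-2-en-1-yl in place of hydrogen on a saturated chain carbon bound to a double-bonded chain carbon also brings a drop (a number 18.1 percentage points lower from compound 1 to compound 4 (beyond the scatter)). Nothing available explains this drop.

On these data alone, whether the drop depends on the carbamate link or on the methoxy-bearing ring remains open. An unsubstituted phenyl carbamate, or a carboxylic acid in place of the methoxy group, would help to separate the two.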